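Ring Oxygen Enters the Side Group of Compound 1

The source may report more compounds than this note shows. Statements on the series, on what has been measured and on what is new or still open speak of the compounds shown alone.

In a functional assay on the whole organism (B cells) with Mus musculus as the target (on this read-out higher numbers stand for larger maximal responses and lower numbers for smaller maximal responses), compound 1 `C=CCn1c(=O)n(C2CCC(CO)C2)c2nc(N)nc(O)c21` gives 26%, the second highest of the three numbers in hand. Compound 2 `CCCCCCCCCCn1c(=O)n(C2OC(CO)[C@@H](O)[C@H]2O)c2nc(N)nc(O)c21` gives 0%, a number lower than that of compound 1 by more than the usual scatter, while compound 3 `Cn1c(=O)n([C@@H]2O[C@H](CO)[C@H]3OC(C)(C)O[C@H]32)c2nc(N)nc(O)c21` gives 193%, far above compound 1 and also beyond the scatter. Going by the values given here, no two of these measured compounds differ in a single place, so no step between them is established. Compound 4 `C=CCn1c(=O)n(C2C=CC(CO)O2)c2nc(N)nc(O)c21` has not yet been measured in this assay. It differs from compound 1 in one place: a group of 7 heavy atoms (5 carbon, 2 oxygen; one five-membered non-aromatic ring with 1 hetero atom) in place of a group of 7 heavy atoms (6 carbon, 1 oxygen; one five-membered non-aromatic ring of carbon only), on an aromatic nitrogen. Compound 2 and compound 3 lie on opposite sides of compound 1, so they give no firm direction for this change. Because compound 3 reaches 193% with a five-membered ring carrying hetero atoms, a modest rise is expected, with the step estimated at a number 14 percentage points higher from compound 1 to compound 4 (beyond the scatter). Compound 4 is therefore estimated to give 40%, within a range from 10% to 90%.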

Compound 4, largest response reached (reported as maximal response), in percent of the reference or control that the assay uses: 45%
The estimate for compound 4 lay 5 percentage points below the measured number; the measured number falls inside the stated range.
By their numbers in this assay, from the lowest: compound 2; then compound 1; then compound 4; then compound 3.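

With the allyl group and the rest of the core of compound 1 unchanged, the side group on the aromatic nitrogen is the only difference, and in this assay the change gives a number 19 percentage points higher from compound 1 to compound 4 (beyond the scatter). Going by these compounds alone, this is the first step at this position that can be read directly, and it shows that the response here moves with the side group alone. The entering group brings a ring oxygen and a double bond outside aromatic rings at once, so the step belongs to the two together, and nothing at hand explains the rise.

The compounds shown leave open how much of the step would remain with the ring oxygen but without the double bond, or with the double bond but without the ring oxygen. They also leave open whether an amine or a carboxylic acid carried on the side group would keep the rise.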